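A few compounds are considered here, and "the series" means these few. Any claim that something is new, unique, unknown or untested is made for them only; others in the source may bear on it.

Compound 1 `Cc1ccc(OCC(=O)N(Cc2cccs2)c2ccnn2C)cc1` gives 422 nM in an assay on HEK293 cells for agonist activity at transient receptor potential cation channel subfamily M member 8 (Homo sapiens), read by fluorescence and calcium flux, with a stated time of 15 min; a higher number here means that more compound is needed for the effect, a lower number that less compound is needed.
Compound 2 `Cc1ccc(OCC(=O)N(CCCO)Cc2cccs2)cc1` gives 3000 nM in this assay.

Among the measured compounds shown here, compound 2 stands highest of the two numbers, needing more compound than compound 1; the only measured step, a 7.1-fold higher number from compound 1 to compound 2 (0.85 log units; beyond the scatter), is modest. Compound 3 `Cc1ccc(OCC(=O)N(Cc2cccs2)C2CC2)cc1` differs from compound 2 by cyclopropyl in place of 3-hydroxypropyl on an amide-type nitrogen. No measured step swaps these two groups directly; the one step shown suggests the 3-hydroxypropyl group is the less favourable partner, so removing it is expected to lower the number, with the step from compound 2 to compound 3 estimated as a 2.5-fold lower number from compound 2 to compound 3 (0.40 log units; beyond the scatter). Compound 3 is expected at 1200 nM, between 400 nM and 4000 nM.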

Compound 3, half-maximal effective concentration: 8 nM
Estimate against measurement, compound 3: 150-fold (2.18 log units) above; measured number below the stated range.
By their numbers in this assay, from the lowest: compound 3; then compound 1; then compound 2.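

The group on the amide-type nitrogen moves the number in this assay far more than the first pair showed: cyclopropyl in place of 3-hydroxypropyl gives a 380-fold lower number from compound 2 to compound 3 (2.57 log units; beyond the scatter). Cyclopropyl also outdoes the 1-methyl-1H-pyrazol-5-yl group, with a 53-fold lower number from compound 1 to compound 3 (1.72 log units; beyond the scatter). Nothing shown here gives a cause for these steps.

From the compounds shown here alone, whether the three-membered ring itself matters, or simply a small group of carbon only, stays open. An isopropyl group or a cyclobutyl ring at this nitrogen would help separate the two.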